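The source may hold more compounds than are shown below. What is called first, only, known or untested is meant among the compounds shown, and "the series" means these compounds.

Compound 1, with the structure `CN1CCN(CCNCc2cn(-c3ccc(F)cc3F)nc2-c2ccccc2)CC1`, was examined in an ADME assay on Huh-7 cells (Homo sapiens) for cytotoxicity; a higher number here means that more compound is tolerated, a lower number that less compound is tolerated. In that test compound 1 gives > 20000 nM, which is a limit of the assay rather than a number. Two other compounds share much of the same core. Compound 2, with the structure `Cc1ccccc1-c1nn(-c2ccc(C(F)(F)F)cc2)cc1CNCCN1CCN(C)CC1`, gives 11000 nM in this assay. Compound 3, with the structure `CCN(CC)CCCNCc1cn(-c2ccc(F)cc2F)nc1-c1ccccc1C`, gives > 20000 nM in this assay, again only a limit. Compound 1 therefore sits at the limit of > 20000 nM in this assay, at which 2 of the 3 values shown sit, and no numbered value places it against the others.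

Compound 4, with the structure `COC(=O)c1ccc(-c2nn(-c3ccc(F)cc3F)cc2CNCCN2CCN(C)CC2)cc1`, has not yet been measured in this assay. It differs from compound 1 in one place: methoxycarbonyl in place of hydrogen on an aromatic carbon. Among the compounds with values here, no pair of measured compounds differs by one such change, so the size of the step cannot be read off and can only be expected. The step in this assay is expected to be a number no higher from compound 1 to compound 4 (the limit leaves the size open), nothing beyond the scatter. Compound 4 is thus estimated at 20000 nM, between 8000 nM and 40000 nM, with a real chance that only a limit is reported once more.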

Compound 4, half-maximal cytotoxic concentration: > 20000 nM
Compound 4: a limit, no number; the forecaster's own chance of this, stated with the estimate: 60%; the middle value sits exactly at the limit.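

Within the data shown here, compound 1 and compound 4 both give only a limit of the assay, so no step between them can be read in this assay. The compounds shown leave open how far methoxycarbonyl in place of hydrogen on an aromatic carbon moves the tolerated concentration, and most values rest on a single limit: the limit of > 20000 nM in this assay, at which 3 of the 4 values shown sit.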